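Removing the amine linker at the core of compound 2

The source may hold more compounds than are shown below. What is called first, only, known or untested is meant among the compounds shown, and "the series" means these compounds.

Compound 1 `CNc1nc(N)c2nc(O)n(Cc3ccccc3)c2n1` and compound 2 `CCCCNc1nc(N)c2nc(O)n(Cc3ccccc3)c2n1` share one core and differ only in the chain on the amine. In a functional assay (spleen, spleen) for activation, with Mus musculus as the target (on this read-out higher numbers stand for an effect only at larger amounts of compound and lower numbers for an effect already at smaller amounts), compound 1 gives 1 uM, and in this assay compound 2 gives 1 uM; the step of no change at the digits printed from compound 1 to compound 2 (within the scatter) shows that lengthening that chain left the read-out unchanged within the scatter. Compound 2 thus stands level with compound 1 on these numbers.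

Compound 3 `CCCc1nc(N)c2nc(O)n(Cc3ccccc3)c2n1` has not been measured. It differs from compound 2 by propyl in place of butylamino on an aromatic carbon. Within the data shown here, the one measured step changed only the length of the chain on the amine; no measured step removes the amine itself, so the data give no direct guide to this change. Among the measured compounds shown here, the account therefore rests on the single point of compound 2 and on wide uncertainty. The step of a 2.0-fold higher number from compound 2 to compound 3 (0.30 log units; within the scatter) is expected to be small, with the range left broad. For compound 3 the estimate in this assay is 2 uM, between 0.3 uM and 15 uM.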

Compound 3, minimum effective concentration: 1 uM
Compound 3: middle estimate off by 2.0-fold (0.30 log units), on the high side, and the stated range covers the measured number.
By their numbers in this assay, from the lowest: compounds 1, 2 and 3 (each within the scatter of the next).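

In this assay, propyl in place of butylamino on this aromatic carbon, between two ring nitrogen atoms, gives no change at the digits printed from compound 2 to compound 3 (within the scatter) and propyl in place of methylamino gives no change at the digits printed from compound 1 to compound 3 (within the scatter) on the same read-out. The earlier step altered only the chain on the amine, whereas these two show that the read-out does not separate compounds with and without that amine nitrogen at this place, even though the hydrogen-bond donor and acceptor counted in butylamino leave with it. Nothing at hand accounts for this result.

The compounds shown leave open whether a butoxy chain, a carboxylic acid or a phenyl ring on this carbon would also read level. All three also keep the benzyl group and the amino group, so replacing either remains an open question.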